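Piperazine for dimethylamino on two related aryl amide cores

The compounds below may be only part of what the source reports. "The series", "measured", "known", "first", "only" and "open" are said of these compounds alone.

Compound 1 `CN(C)c1ccc(C(=O)Nc2n[nH]c3c2CN(Cc2cc(F)cc(F)c2)C3(C)C)cc1` and compound 2 `CN1CCN(c2ccc(C(=O)Nc3n[nH]c4c3CN(Cc3cc(F)cc(F)c3)C4(C)C)cc2)CC1` share one core and differ in a single place: 4-methylpiperazin-1-yl in place of dimethylamino on an aromatic carbon. In an assay on Sf21 cells for inhibition of high affinity nerve growth factor receptor (Homo sapiens), read by HTRF, with a stated time of 30 min, in the presence of a further agent that is not named here (a higher number here means a weaker inhibitor, a lower number a stronger inhibitor), compound 1 gives 96 nM, while compound 2 gives 17 nM; the change brought a 5.6-fold lower number from compound 1 to compound 2 (0.75 log units; beyond the scatter). Compound 3 `CN(C)c1cccc(C(=O)Nc2n[nH]c3c2CN(Cc2cccc(F)c2F)C3(C)C)c1` has the same atoms as compound 1, joined differently; the difference between the two cores is not broken down here. In this assay, going by the values given here, compound 3 gives 420 nM, the highest of the three numbers so far. Compound 4 `CN1CCN(c2cccc(C(=O)Nc3n[nH]c4c3CN(Cc3cccc(F)c3F)C4(C)C)c2)CC1` stands to compound 3 as compound 2 stands to compound 1: 4-methylpiperazin-1-yl in place of dimethylamino on an aromatic carbon. It is the same kind of change rather than the same one, for in compound 1 the place is para to a large group, whereas in compound 3 it is meta to a large group. The step is expected to be a 4.4-fold lower number from compound 3 to compound 4 (0.65 log units; beyond the scatter), resting on the measured step of a 5.6-fold lower number from compound 1 to compound 2 (0.75 log units; beyond the scatter) and taken somewhat smaller, as the surroundings of the place are not identical. Compound 4 is therefore estimated to give about 95 nM in this assay, most likely between 40 nM and 250 nM.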

Compound 4, half-maximal inhibitory concentration: 210 nM
Beside the measured number, compound 4's estimate is 2.2-fold (0.34 log units) below it; measured number inside the range.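

In this assay, replacing dimethylamino with 4-methylpiperazin-1-yl did not carry over at full size from one core to the other: the same change on two cores in this assay, a 5.6-fold lower number (0.75 log units; beyond the scatter) from compound 1 to compound 2 and a 2.0-fold lower number (0.30 log units; within the scatter) from compound 3 to compound 4, 2.8-fold (0.45 log units) apart, beyond the scatter of two such steps On the core of compound 3, with the group meta to a large group, the change gave a 2.0-fold lower number from compound 3 to compound 4 (0.30 log units; within the scatter), so this pair gives no firm sign that the change makes a difference on that core. The two pairs show that the size of the step is not fixed across these cores, but the cores differ in more than one place, so they do not show which difference sets the steps apart.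

The compounds shown leave open whether the gap follows the place of the group on the aromatic ring or the placing of the fluorines on the other ring. They also leave open how other cyclic amines, such as morpholine or piperidine, would behave at this place on either core.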